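The compounds below may be only part of what the source reports. "The series", "measured", "known", "first", "only" and "open" are said of these compounds alone.

In an ADME assay on Vero cells (Chlorocebus sabaeus) for cytotoxicity, read by CellTiter-Glo and ATP content, with a stated time of 72 h (on this read-out higher numbers stand for lower toxicity in this test and lower numbers for higher toxicity in this test), compound 1 (`Nc1c(C2=NCCN2)cnn1-c1cccc(Cl)c1`) gives > 500000 nM as a limit of the assay and not a number. Compound 3 (`Nc1c(C2=NCCN2)cnn1-c1ccc(F)cc1`) likewise gives > 500000 nM as a limit of the assay. Among the measured compounds shown here, compound 2 (`Nc1c(C2=NCCN2)cnn1-c1cc(Cl)cc(Cl)c1`) gives 257000 nM as the only true number among the three.

The change to compound 4 (`Nc1c(C2=NCCCN2)cnn1-c1cc(Cl)cc(Cl)c1`) is a group of 6 heavy atoms (4 carbon, 2 nitrogen; one six-membered non-aromatic ring with 2 hetero atoms) in place of a group of 5 heavy atoms (3 carbon, 2 nitrogen; one five-membered non-aromatic ring with 2 hetero atoms), on an aromatic carbon on an aromatic carbon of a five-membered aromatic ring with 2 nitrogen, next to the ring atom that bears an amino group. For the measured compounds named here, the one measured step (an at least 1.9-fold lower number from compound 1 to compound 2 (0.28 log units; that floor lies within the scatter)) is chloro in place of hydrogen on an aromatic carbon, a change at another place, so no measured step touches this ring. Compound 2 at 257000 nM is therefore the only anchor for the expectation. No step beyond the scatter is expected in this assay and no direction can be argued, so the expected step is a 1.3-fold lower number from compound 2 to compound 4 (0.11 log units; within the scatter) in size. Compound 4 is estimated at 200000 nM with an expected range from 90000 nM to 450000 nM in this test.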

Compound 4, half-maximal cytotoxic concentration: > 500000 nM
Compound 4 ended at the assay's limit; the forecaster's own chance of this, stated with the estimate: 25%; middle value at least 2.5-fold (0.39 log units) from the limit.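

Among the compounds shown here, the first measured step at this place, on an aromatic carbon of a five-membered aromatic ring with 2 nitrogen, next to the ring atom that bears an amino group, is in this assay an at least 1.9-fold higher number from compound 2 to compound 4 (0.28 log units; that floor lies within the scatter). Compound 4 gives > 500000 nM, which is a limit of the assay and not a number. Only a floor of this step can be read, and its true size stays unknown, because most values shown stop at one ceiling: the limit of > 500000 nM in this assay, at which 3 of the 4 values shown sit.

Going by these compounds, whether an open-chain amine or a carboxylic acid at this place would give a true number in this assay remains open. Also open, on these data alone, is how the six-membered ring reads when paired with the aromatic group of compound 1 or compound 3.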